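Amide Substituent and Solubility: Aziridine to Methylamino

This account rests on a few compounds, and the source may have more. Where it says the series, first, only, none or still open, it means among the compounds named here.

Measured compounds:
compound 1, `CCNC(=O)c1cc(N)c(Nc2ccc(C#N)cc2)cc1Oc1c(C)cc(/C=C/C#N)cc1C`, gives 69.4 ug/mL
compound 2, `Cc1cc(/C=C/C#N)cc(C)c1Oc1cc(Nc2ccc(C#N)cc2)c(N)cc1C(N)=O`, gives 2.09 ug/mL
compound 3, `Cc1cc(/C=C/C#N)cc(C)c1Oc1cc(Nc2ccc(C#N)cc2)c(N)cc1C(=O)N1CC1`, gives 94.2 ug/mL

In a physicochemical assay for solubility, read by HPLC, with a stated time of 4 h, at pH 2 (on this read-out higher numbers stand for higher solubility and lower numbers for lower solubility), compound 3 returns the largest of the three numbers, but a 1.4-fold higher number from compound 1 to compound 3 (0.13 log units; within the scatter) lies within the scatter, so compound 3 and compound 1 cannot be told apart on this read-out. Only a 45-fold higher number from compound 2 to compound 3 (1.65 log units; beyond the scatter) sets compound 3 clearly apart, and in the same sense a 33-fold lower number from compound 1 to compound 2 (1.52 log units; beyond the scatter) marks compound 2 as the outlier of the set.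

Compound 4, `CNC(=O)c1cc(N)c(Nc2ccc(C#N)cc2)cc1Oc1c(C)cc(/C=C/C#N)cc1C`, is made from compound 3 by methylamino in place of aziridin-1-yl on a carbonyl carbon. Within the data shown here, two measured steps bear on this. Replacing one alkylamino group on the carbonyl carbon by the aziridin-1-yl group gave a 1.4-fold higher number from compound 1 to compound 3 (0.13 log units; within the scatter), a change within the scatter, whereas losing the alkyl group from the amide nitrogen altogether gave a 33-fold lower number from compound 1 to compound 2 (1.52 log units; beyond the scatter). Methylamino keeps an alkyl group on the amide nitrogen, as ethylamino does, and the measured data give no reason to expect the large drop seen for compound 2.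

The step is therefore expected to be small, a 1.7-fold lower number from compound 3 to compound 4 (0.23 log units; within the scatter), and likely within the scatter. Compound 4 is estimated at 55 ug/mL in this assay, with a range from 18 ug/mL to 160 ug/mL.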

Compound 4, solubility: 44.7 ug/mL
Compound 4: middle estimate off by 1.2-fold (0.09 log units), on the high side; the range from low to high includes it.
By their numbers in this assay, from the lowest: compound 2; then compounds 4, 1 and 3 (each within the scatter of the next, the first and the last beyond it).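

In this assay, methylamino on the carbonyl carbon stays far from the amino group of compound 2 (a 21-fold higher number from compound 2 to compound 4 (1.33 log units; beyond the scatter)), while the shorter alkyl group cannot be told apart from ethylamino (a 1.6-fold lower number from compound 1 to compound 4 (0.19 log units; within the scatter)). The change from aziridin-1-yl to methylamino is modest but beyond the scatter (a 2.1-fold lower number from compound 3 to compound 4 (0.32 log units; beyond the scatter)), so compound 3 and compound 4 can be told apart even though compound 1 lies within the scatter of both, which makes the differences among these three substituted amides small beside their gap to compound 2. No measurement shown here explains these differences.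

The compounds shown leave open whether a longer chain such as propylamino, or a larger ring such as pyrrolidin-1-yl or morpholin-4-yl, on the same carbonyl carbon would stay close to compound 1, compound 3 and compound 4 or fall toward compound 2. They also leave open where dimethylamino would land, a group with two methyl groups, no ring and no amide hydrogen, which would help separate the loss of the ring from the gain of that hydrogen in this change.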